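Sulfonyl Capping of a Phenol on Two Related Cores

The source may report more compounds than this note shows. Statements on the series, on what has been measured and on what is new or still open speak of the compounds shown alone.

Compound 1 `Cc1c(O)ccc2c1[C@H](Cn1cc(-c3ccccc3)nn1)[C@@]13CC(=O)[C@@](C)(CC[C@@H]21)C3`: > 20000 nM
Compound 2 `Cc1ccc(S(=O)(=O)Oc2ccc3c(c2C)[C@H](Cn2cc(-c4ccccc4)nn2)[C@@]24CC(=O)[C@@](C)(CC[C@@H]32)C4)cc1`: > 20000 nM
Compound 3 `C=C1C[C@]23C[C@@]1(O)CC[C@H]2c1ccc(O)c(C)c1[C@@H]3Cn1cc(-c2ccccc2)nn1`: > 20000 nM

All three were tested in a functional assay on HL-60 cells (Homo sapiens) for cytotoxicity, read by MTT assay, with a stated time of 4 days; on this read-out higher numbers stand for weaker inhibition and lower numbers for stronger inhibition. For compound 1 the value of > 20000 nM is a limit of the assay, not a number. For compound 2 the value of > 20000 nM is likewise a limit. For compound 3 the value of > 20000 nM is a limit as well.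

Compound 2 comes from compound 1 by one change, ((4-methylphenyl)sulfonyl in place of hydrogen on an oxygen on an aromatic ring). Its size in this assay, a step that the two limits leave unreadable from compound 1 to compound 2, cannot be read, since both ends are limits. The cores of compound 1 and compound 3 differ; that difference is not broken down here.

Compound 4 `C=C1C[C@]23C[C@@]1(O)CC[C@H]2c1ccc(OS(=O)(=O)c2ccc(C)cc2)c(C)c1[C@@H]3Cn1cc(-c2ccccc2)nn1` is not yet measured. It comes from compound 3 by (4-methylphenyl)sulfonyl in place of hydrogen on an oxygen on an aromatic ring, the same change as from compound 1 to compound 2, made at the same kind of place. In this assay the step from compound 3 to compound 4 is expected to be a step that the limit leaves unreadable from compound 3 to compound 4, because every value shown sits at the limit of > 20000 nM in this assay, at which 3 of the 3 values shown sit, and the parent change gave no readable movement. Compound 4 is therefore expected to give about 30000 nM, most likely reported again as a limit, with a range from 15000 nM to 100000 nM.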

Compound 4, half-maximal inhibitory concentration: > 20000 nM
Compound 4: a limit, no number; the forecaster's own chance of this, stated with the estimate: 85%; the middle value lies beyond the limit too.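

In this assay compound 4 gives > 20000 nM, which is a limit and not a number. No size can be read for the step from compound 3 to compound 4, just as none can be read from compound 1 to compound 2. The compounds shown leave open whether the (4-methylphenyl)sulfonyl group changes cytotoxicity at all, and how strongly any of the four compounds acts, with every result sitting at one value: the limit of > 20000 nM in this assay, at which 4 of the 4 values shown sit.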